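Moving the Pyridine Nitrogen on the Alkyne Arm

The compounds below may be only part of what the source reports. "The series", "measured", "known", "first", "only" and "open" are said of these compounds alone.

Measured in an assay on CHO cells for displacement of a labelled ligand from adenosine receptor A3 (Homo sapiens); a lower number here means a stronger inhibitor, a higher number a weaker inhibitor:
compound 1, `CONc1nc(C#CC2CCCCC2O)nc2c1ncn2[C@@H]1O[C@H](CO)[C@@H](O)[C@H]1O`, gives 1.7 nM
compound 2, `CONc1nc(C#Cc2ccccn2)nc2c1ncn2[C@@H]1O[C@H](CO)[C@@H](O)[C@H]1O`, gives 2.3 nM
compound 3, `CONc1nc(C#Cc2cccnc2)nc2c1ncn2[C@@H]1O[C@H](CO)[C@@H](O)[C@H]1O`, gives 7.9 nM

Compound 3 stands at the highest number of the three in this assay, with compound 2 nearest and compound 1 furthest away. Compound 4, `CONc1nc(C#Cc2ccncc2)nc2c1ncn2[C@@H]1O[C@H](CO)[C@@H](O)[C@H]1O`, differs from it by pyridin-4-yl in place of pyridin-3-yl on a triple-bonded carbon. Going by the values given here, no measured step covers this exact change. The one that comes closest is a 3.4-fold higher number from compound 2 to compound 3 (0.54 log units; beyond the scatter), which moved the ring nitrogen by one position and gave a modest step beyond the scatter; the steps of a 1.4-fold higher number from compound 1 to compound 2 (0.13 log units; within the scatter) and a 4.6-fold higher number from compound 1 to compound 3 (0.67 log units; beyond the scatter) replace the ring altogether and bear less directly. A further shift of the nitrogen is therefore expected to give at most a modest step, in either direction or none beyond the scatter, estimated as a 1.1-fold higher number from compound 3 to compound 4 (0.06 log units; within the scatter). Compound 4 is expected to give 9 nM, within 3 nM to 30 nM.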

Compound 4, inhibition constant: 6 nM
Estimate against measurement, compound 4: 1.5-fold (0.18 log units) above, and the stated range covers the measured number.
By their numbers in this assay, from the lowest: compounds 1 and 2 (each within the scatter of the next); then compounds 4 and 3 (each within the scatter of the next).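

In this assay, moving the ring nitrogen gives a 1.3-fold lower number from compound 3 to compound 4 (0.12 log units; within the scatter), so pyridin-3-yl and pyridin-4-yl on the triple-bonded carbon cannot be told apart. Pyridin-4-yl also shows a 2.6-fold higher number from compound 2 to compound 4 (0.42 log units; beyond the scatter) and a 3.5-fold higher number from compound 1 to compound 4 (0.55 log units; beyond the scatter), both beyond the scatter, so the gap first seen with pyridin-3-yl appears again with this second ring placement. Nothing measured here accounts for these differences.

Still open, as far as these compounds go, is whether a plain phenyl ring at this place, or a pyridine carrying an amine or a carboxylic acid, would match pyridin-2-yl or the other two pyridines.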